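Adding a Third Methoxy Group to a Dimethoxybenzyl Side Chain

This account rests on a few compounds, and the source may have more. Where it says the series, first, only, none or still open, it means among the compounds named here.

Of the compounds shown here, three sharing one core have been tested in a functional assay on MIA PaCa-2 cells (Homo sapiens) for antiproliferative activity, read by sulforhodamine B assay, with a stated time of 48 h; a higher number here means a weaker inhibitor of growth, a lower number a stronger inhibitor of growth. Compound 1 `COc1cc(Cn2cc(CNC(=O)c3cn(-c4ccccc4)nc3-c3ccc(F)cc3)nn2)cc(OC)c1OC` gives 5200 nM. Compound 2 `O=C(NCc1cn(Cc2ccc(F)cc2)nn1)c1cn(-c2ccccc2)nc1-c1ccc(Cl)cc1` gives 1990 nM. Compound 3 `COc1cc(Cn2cc(CNC(=O)c3cn(-c4ccccc4)nc3-c3ccc(Cl)cc3)nn2)cc(OC)c1` gives 340 nM, the lowest number of the three; the gaps to compound 2 and to compound 1 both lie beyond the scatter of repeat measurements. Going by the values given here, the single step between neighbours that differ in one place is a 5.9-fold lower number from compound 2 to compound 3 (0.77 log units; beyond the scatter).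

Compound 4 `COc1cc(Cn2cc(CNC(=O)c3cn(-c4ccccc4)nc3-c3ccc(Cl)cc3)nn2)cc(OC)c1OC` is compound 3 with one change: methoxy in place of hydrogen on an aromatic carbon. Among the compounds with values here, no measured pair isolates this change. Compound 1, which also carries the 3,4,5-trimethoxyphenyl group, has the highest number of the three, but it also carries a different halogen on the core, so its value cannot be read as a clean test of the added methoxy group. Given that compound 1 sits at 5200 nM while compound 3 sits at 340 nM, the expected step is a 2.9-fold higher number from compound 3 to compound 4 (0.47 log units; beyond the scatter), a modest rise. Compound 4 is therefore estimated at 1000 nM, with a range of 250 nM to 4000 nM.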

Compound 4, concentration for 50% growth inhibition: 3500 nM
For compound 4 the middle estimate is 3.5-fold (0.54 log units) below the measured one; the measured number falls inside the stated range.
By their numbers in this assay, from the lowest: compound 3; then compounds 2, 4 and 1 (each within the scatter of the next, the first and the last beyond it).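

The first clean test of this change shows that a methoxy group on the aromatic carbon ortho to two methoxy groups and para to a large group sharply weakens growth inhibition (a 10-fold higher number from compound 3 to compound 4 (1.01 log units; beyond the scatter)). With this group added, the 3,4,5-trimethoxyphenyl side chain no longer stands apart from the 4-fluorophenyl side chain (a 1.8-fold higher number from compound 2 to compound 4 (0.25 log units; within the scatter)), so the advantage held by the 3,5-dimethoxyphenyl side chain of compound 3 is gone. Chloro in place of fluoro on the core also stays within the scatter (a 1.5-fold lower number from compound 1 to compound 4 (0.17 log units; within the scatter)), so the high number of compound 1 goes with its 3,4,5-trimethoxyphenyl group rather than its halogen.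

Nothing available explains why the added methoxy group has this effect. On these data alone, whether a hydroxyl group, a fluoro group or an ethoxy group on the same carbon would give a similar result remains open.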